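The source may report more compounds than this note shows. Statements on the series, on what has been measured and on what is new or still open speak of the compounds shown alone.

Compounds measured so far in a functional assay on HEK293 cells for agonist activity at Vasopressin V2 receptor (Homo sapiens), read by a luciferase reporter and cAMP accumulation; a higher number here means that more compound is needed for the effect, a lower number that less compound is needed:
compound 1 `Cc1cc(C(=O)N2CCCCc3ccccc32)ccc1CNC(=O)Nc1ccccc1`, 130 nM
compound 2 `Cc1cc(C(=O)N2CCCCc3ccccc32)ccc1CNC(=O)NCC(N)=O`, 210 nM
compound 3 `Cc1cc(C(=O)N2CCCCc3ccccc32)ccc1CNC(=O)NCC(=O)N(C)C`, 58 nM

Compound 3 stands at the lowest of the three numbers: a 2.2-fold lower number from compound 1 to compound 3 (0.35 log units; beyond the scatter) and a 3.6-fold lower number from compound 2 to compound 3 (0.56 log units; beyond the scatter), both beyond the scatter, whereas a 1.6-fold higher number from compound 1 to compound 2 (0.21 log units; within the scatter). Compound 4 `Cc1cc(C(=O)N2CCCCc3ccccc32)ccc1CNC(=O)N1CCC[C@H]1C(=O)OC(C)(C)C` has not been measured. It differs from compound 3 in one place: 2-(tert-butoxycarbonyl)pyrrolidin-1-yl in place of ((dimethylcarbamoyl)methyl)amino on a carbonyl carbon. The two steps that bear on this change are those already given into compound 3, since each also replaced the group on the same carbonyl carbon; both were modest. The entering group is larger and ring-bearing, unlike anything measured here, so the outcome is uncertain, and only a small move in this assay is expected. Compound 4 is estimated at 110 nM, with a range from 30 nM to 400 nM, meaning a 1.9-fold higher number from compound 3 to compound 4 (0.28 log units; within the scatter) is expected.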

Compound 4, half-maximal effective concentration: 390 nM
Estimate against measurement, compound 4: 3.5-fold (0.55 log units) below, and the stated range covers the measured number.
By their numbers in this assay, from the lowest: compound 3; then compounds 1, 2 and 4 (each within the scatter of the next, the first and the last beyond it).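

In this assay, the 2-(tert-butoxycarbonyl)pyrrolidin-1-yl group on this carbonyl carbon gives up what the (dimethylcarbamoyl)methyl side chain had gained (a 6.7-fold higher number from compound 3 to compound 4 (0.83 log units; beyond the scatter)) and also falls behind the anilino group (a 3.0-fold higher number from compound 1 to compound 4 (0.48 log units; beyond the scatter)), while its gap to the (carbamoylmethyl)amino group stays within the scatter (a 1.9-fold higher number from compound 2 to compound 4 (0.27 log units; within the scatter)). The change alters the ring, the size and the hydrogen-bond donors together, so this step cannot separate them. Whether a plain pyrrolidine or the free carboxylic acid would behave differently remains open, and no measurement here explains the change.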